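The source may report more compounds than this note shows. Statements on the series, on what has been measured and on what is new or still open speak of the compounds shown alone.

Measured so far:
Compound 1, `O=C1/C(=C/c2ccncc2)CN(S(=O)(=O)c2ccc(Cl)cc2)C/C1=C\c1ccccc1F`: 15000 nM
Compound 2, `O=C1/C(=C/c2ccncc2)CN(S(=O)(=O)c2ccc(Br)cc2)C/C1=C\c1ccccc1F`: 19400 nM
Compound 3, `O=C1/C(=C/c2cccnc2)CN(S(=O)(=O)c2ccc(Cl)cc2)C/C1=C\c1ccccc1C(F)(F)F`: 11900 nM

All three were tested in an ADME assay on L02 cells (Homo sapiens) for cytotoxicity, read by MTT assay, with a stated time of 24 h; on this read-out higher numbers stand for weaker inhibition and lower numbers for stronger inhibition. Compound 1 gives 15000 nM there, compound 2 gives 19400 nM, and compound 3 gives 11900 nM. The three numbers lie close together, and none of them can be set apart from the others on this read-out.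

Compound 1 and compound 2 share one core and differ only by bromo in place of chloro on an aromatic carbon. That change made the step of a 1.3-fold higher number from compound 1 to compound 2 (0.11 log units; within the scatter). Compound 3 and compound 1 have different cores; the difference between the two cores is not broken down here.

The compound still to be measured is compound 4, `O=C1/C(=C/c2cccnc2)CN(S(=O)(=O)c2ccc(Br)cc2)C/C1=C\c1ccccc1C(F)(F)F`. It stands to compound 3 exactly as compound 2 stands to compound 1: it differs by bromo in place of chloro on an aromatic carbon, the same change at the same kind of place.

Among the compounds with values here, since the only measured instance of this change is the step from compound 1 to compound 2, the expectation for compound 4 rests on that one step alone. Compound 4 is therefore expected to show a 1.3-fold higher number from compound 3 to compound 4 (0.10 log units; within the scatter) against compound 3, because a 1.3-fold higher number from compound 1 to compound 2 (0.11 log units; within the scatter) stayed within the scatter. For compound 4 the estimated value in this assay is 15000 nM, with a likely range from 8000 nM to 28000 nM.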

Compound 4, half-maximal inhibitory concentration: 13300 nM
For compound 4 the middle estimate is 1.1-fold (0.05 log units) above the measured one; the measured number falls inside the stated range.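

In this assay, putting bromo in place of chloro on the core of compound 3 gave a 1.1-fold higher number from compound 3 to compound 4 (0.05 log units; within the scatter). Set beside the only other example of this change, the two steps agree: the same change on two cores in this assay, a 1.3-fold higher number (0.11 log units; within the scatter) from compound 1 to compound 2 and a 1.1-fold higher number (0.05 log units; within the scatter) from compound 3 to compound 4, 1.2-fold (0.06 log units) apart, within the scatter of two such steps. This shows that, for these two pairs, the swap left the number within the scatter on either core, so the earlier step was a fair guide to the new one; it does not show that the swap has any real effect on this read-out, and it does not show that a change with a large effect would carry over in the same way, since two small steps that match say little about how much the core matters.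

The compounds shown leave open what a group very unlike a halogen, such as an amine or a carboxylic acid, would do in place of the chloro or bromo on that aromatic carbon. They also leave open whether a step from such a group, if it proved larger than the scatter, would keep its size when moved from the core of compound 1 to the core of compound 3.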